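Urea aryl variation on the shared core: compound 4

A few compounds are considered here, and "the series" means these few. Any claim that something is new, unique, unknown or untested is made for them only; others in the source may bear on it.

Measured so far in a functional assay on RT-112 cells (Homo sapiens) for antiproliferative activity, read by MTT assay, with a stated time of 72 h; on this read-out lower numbers stand for stronger inhibition of growth and higher numbers for weaker inhibition of growth:
compound 1 `COc1cc(Nc2ncnc3c(NC(=O)Nc4ccc(C)cc4C)cccc23)cc(OC)c1`: 1290 nM
compound 2 `COc1cc(Nc2ncnc3c(NC(=O)Nc4ccccc4Cl)cccc23)cc(OC)c1`: 356 nM
compound 3 `COc1cc(Nc2ncnc3c(NC(=O)Nc4cc(C(F)(F)F)cc(C(F)(F)F)c4)cccc23)cc(OC)c1`: 467 nM

Compound 2 gives the lowest of the three numbers in this assay. Compound 3 sits nearest to it, and the two values lie within the scatter of each other, so no order between them is claimed. Compound 1 is furthest away; the step of a 3.6-fold lower number from compound 1 to compound 2 (0.56 log units; beyond the scatter) is the only one in the set that is beyond the scatter.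

Compound 4 `COc1cc(Nc2ncnc3c(NC(=O)Nc4cccc(C)c4C)cccc23)cc(OC)c1` is the next member, not yet measured. The change from compound 2 is 2,3-dimethylphenyl in place of 2-chlorophenyl on an amide-type nitrogen. Within the data shown here, the step that bears on it is the one from compound 1 to compound 2, read in reverse: there a dimethylphenyl was replaced by the 2-chlorophenyl and the number fell, a 3.6-fold lower number from compound 1 to compound 2 (0.56 log units; beyond the scatter). Among the measured compounds shown here, compound 4 carries a dimethylphenyl again, though with the methyls placed as 2,3-dimethylphenyl rather than 2,4-dimethylphenyl, and no measured pair tells how much that placement matters. An upward step from compound 2 is therefore expected in this assay, of roughly the size seen between compound 1 and compound 2 but with wide uncertainty. The expected step is a 2.5-fold higher number from compound 2 to compound 4 (0.40 log units; beyond the scatter). Compound 4 is estimated at 900 nM in this assay, within a range of 350 nM to 2500 nM.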

Compound 4, concentration for 50% growth inhibition: 5910 nM
For compound 4 the middle estimate is 6.6-fold (0.82 log units) below the measured one; measured number above the stated range.
By their numbers in this assay, from the lowest: compounds 2 and 3 (each within the scatter of the next); then compound 1; then compound 4.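

In this assay the placement of the methyls on the urea aryl ring counts on its own: 2,3-dimethylphenyl in place of 2,4-dimethylphenyl gives a 4.6-fold higher number from compound 1 to compound 4 (0.66 log units; beyond the scatter) and so the two dimethylphenyl groups are not interchangeable on this amide-type nitrogen. The exchange of 2-chlorophenyl for 2,3-dimethylphenyl gives a 17-fold higher number from compound 2 to compound 4 (1.22 log units; beyond the scatter) and is the largest step in the set, well beyond what the earlier dimethylphenyl comparison showed. No measurement at hand accounts for either step.

Going by these compounds, it stays open whether a phenyl carrying a single methyl, or an unsubstituted phenyl, would read closer to compound 2 or to compound 4. On these data alone, how an amine or a carboxylic acid on this aryl ring would read on the shared core also stays open.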